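The source may report more compounds than this note shows. Statements on the series, on what has been measured and on what is new or still open speak of the compounds shown alone.

Measured compounds:
compound 1, `C[C@@H](Oc1cc2ccn(CCC(=O)O)c2cc1Cl)c1ccccn1`, giving 2.17 in a physicochemical assay for lipophilicity, read by HPLC, at pH 7.4; on this read-out higher numbers stand for higher lipophilicity and lower numbers for lower lipophilicity
compound 2, `O=C(O)CCn1c(=O)oc2cc(OCc3ccccc3)c(Cl)cc21`, giving 2.71 in this assay
compound 3, `C[C@@H](Oc1cc2onc(CCC(=O)O)c2cc1Cl)c1ccccn1`, giving 1.99 in this assay

Of the compounds shown here, three have been measured in this assay, and compound 2 stands highest of them. Compound 1 gives a lower number, and the gap between the two lies beyond the usual scatter of repeated measurements. Compound 3 gives a number lower still, and that gap also lies beyond the scatter. No two of these three compounds differ from one another in a single place, so none of them shows what one isolated change does to this read-out.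

Compound 4, `O=C(O)CCn1c(=O)oc2cc(Cl)c(Cl)cc21`, has not yet been measured. It differs from compound 2 in one place: chloro in place of benzyloxy on an aromatic carbon. The benzyloxy group that leaves is large, eight heavy atoms with a six-membered aromatic ring of carbon only, while the chloro group that enters is a single heavy atom. Among the measured compounds shown here, with no measured step of this kind to lean on, the expectation rests on the size of what is removed, and a drop beyond the scatter is expected, a number 0.81 log units lower from compound 2 to compound 4 (beyond the scatter). For compound 4 the value in this assay is estimated at 1.9, in a range from 1.4 to 2.4.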

Compound 4, distribution coefficient: 1.61
The estimate for compound 4 lay 0.29 log units above the measured number, within the range that was stated.
By their numbers in this assay, from the lowest: compound 4; then compounds 3 and 1 (each within the scatter of the next); then compound 2.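

In this assay the change to chloro in place of benzyloxy on an aromatic carbon gives a number 1.10 log units lower from compound 2 to compound 4 (beyond the scatter) as the first change in one place alone among these compounds. It shows that the read-out is sensitive to what sits on this carbon, ortho to a chloro group, at least when a group of eight heavy atoms with a ring gives way to a single heavy atom. Nothing measured here accounts for the size of this step.

A single step cannot show how the number tracks the size of the group, so a methoxy group or a plain hydrogen on this carbon remains an open case. Also open, as far as these compounds go, is whether the same swap on the core of compound 1 or compound 3 would give a similar step.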